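Replacing azetidin-1-yl with (3-fluorophenyl)amino on the shared core

The source may hold more compounds than are shown below. What is called first, only, known or untested is meant among the compounds shown, and "the series" means these compounds.

In a functional assay on HeLa cells (Homo sapiens) for inhibition, read by sulforhodamine B assay (a higher number here means a weaker inhibitor, a lower number a stronger inhibitor), compound 1 (`O=C1C=C(N2CCC2)C(=O)c2c1nc1n2[C@H]2OC[C@@H](O)[C@H]2OC1`) gives > 16000 nM, which is a limit of the assay and not a number. It therefore stands at the limit of > 16000 nM in this assay, at which 1 of the 3 values shown sits.

Compound 4 (`O=C1C=C(Nc2cccc(F)c2)C(=O)c2c1nc1n2[C@H]2OC[C@@H](O)[C@H]2OC1`) departs from compound 1 in one place: (3-fluorophenyl)amino in place of azetidin-1-yl on a double-bonded ring carbon. In short, (3-fluorophenyl)amino stands in place of azetidin-1-yl on a double-bonded ring carbon.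

Among the compounds with values here, no measured step covers this exchange directly. The nearest evidence comes from two compounds that also bear a substituted phenylamino group on that carbon. Compound 2 (`CCc1ccc(NC2=CC(=O)c3c(nc4n3[C@H]3OC[C@@H](O)[C@H]3OC4)C2=O)cc1`) gives 6510 nM, and compound 3 (`Cc1ccc(NC2=CC(=O)c3c(nc4n3[C@H]3OC[C@@H](O)[C@H]3OC4)C2=O)cc1`) gives 6590 nM. Within the data shown here, the one measured step between them, a 1.0-fold higher number from compound 2 to compound 3 (0.01 log units; within the scatter), concerns only the chain on the aromatic ring, and it suggests that a small change there need not move the value much. Fluorine itself has not been tested on this core, so the range must stay wide.

A move toward a lower number, meaning a stronger inhibitor, is therefore expected, with the true size left open by the limit at its start. The estimated step is an at least 2.6-fold lower number from compound 1 to compound 4 (0.42 log units; beyond the scatter). For compound 4 the expected value is 6000 nM, with an estimated range of 2500 nM to 15000 nM.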

Compound 4, half-maximal inhibitory concentration: 6440 nM
For compound 4 the middle estimate is 1.1-fold (0.03 log units) below the measured one, and the stated range covers the measured number.
By their numbers in this assay, from the lowest: compounds 4, 2 and 3 (each within the scatter of the next). At a limit, above all of these: compound 1.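

Within the data shown here, the step in this assay, an at least 2.4-fold lower number from compound 1 to compound 4 (0.39 log units; beyond the scatter), gives the first direct reading of an exchange on this double-bonded ring carbon, and it lies beyond the scatter. Compound 1 stands at a limit of the assay and not a number, so this step gives only the smallest change that fits the data: the limit of > 16000 nM in this assay, at which 1 of the 4 values shown sits. Compound 4 also shows that a phenylamino group carrying fluorine gives a measured number, as the phenylamino groups carrying ethyl in compound 2 and methyl in compound 3 do, so among the compounds shown only the azetidin-1-yl group stays at the limit.

The compounds shown do not separate the part played by the aromatic ring from that of the hydrogen on the nitrogen, a question that an unsubstituted phenylamino group, a cyclohexylamino group or a piperidin-1-yl group on that carbon would address. From the compounds shown here alone, it also remains open how the number would respond to a methoxy group, a chlorine or a carboxylic acid on the phenyl ring.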